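Notes on a 5-methylfuran-2-yl analogue of compound 1

The source may hold more compounds than are shown below. What is called first, only, known or untested is meant among the compounds shown, and "the series" means these compounds.

Within the data shown here, in a functional assay on blood (Homo sapiens), with a stated time of 60 min, in the presence of a further agent that is not named here (on this read-out lower numbers stand for an effect already at smaller amounts and higher numbers for an effect only at larger amounts of compound), compound 1 (`Nc1ccccc1NC(=O)C1(S(=O)(=O)c2ccc(Oc3ccc(OC(F)(F)F)cc3)cc2)CCC2(CCNCC2)C1`) gives 900 nM, the only exact number so far. Compound 2 (`O=C(Nc1ccccc1O)C1(S(=O)(=O)c2ccc(Oc3ccc(OC(F)(F)F)cc3)cc2)CCC2(CCNCC2)C1`) gives only a limit of the assay, > 15000 nM.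

Compound 3 (`Cc1ccc(-c2ccc(N)c(NC(=O)C3(S(=O)(=O)c4ccc(Oc5ccc(OC(F)(F)F)cc5)cc4)CCC4(CCNCC4)C3)c2)o1`) keeps the amino group of compound 1 and differs as follows: 5-methylfuran-2-yl in place of hydrogen on an aromatic carbon. This places 5-methylfuran-2-yl in place of hydrogen on an aromatic carbon, para to an amino group.

Among the measured compounds shown here, the single measured step, an at least 16-fold higher number from compound 1 to compound 2 (1.22 log units; beyond the scatter), is large, but it replaces the amino group with hydroxy, and compound 3 retains that amino group. For the measured compounds named here, no measured step concerns the new place, so no step beyond the scatter is expected, and the uncertainty runs in both directions. The estimated step is a 1.3-fold lower number from compound 1 to compound 3 (0.11 log units; within the scatter). For compound 3, the expected value in this assay is 700 nM, with an estimated range of 150 nM to 4000 nM.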

Compound 3, half-maximal effective concentration: > 15000 nM
Compound 3: only a limit was reported; the forecaster's own chance of this, stated with the estimate: 10%; middle value at least 21-fold (1.33 log units) away from the limit.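

Up to now no measured step touched this position, and the amino group seemed to be the feature that mattered. Compound 3 keeps that amino group, yet 5-methylfuran-2-yl on the aromatic carbon para to it gives an at least 16-fold higher number from compound 1 to compound 3 (1.22 log units; beyond the scatter) in this assay, so this position is not free to change. Compound 3 gives > 15000 nM, which is a limit of the assay and not a number, so the step sets only a lower bound on the change and its full size cannot be read: the limit of > 15000 nM in this assay, at which 2 of the 3 values shown sit.

The compounds shown leave open whether the higher number goes with 5-methylfuran-2-yl itself or with any substituent at this carbon. A methyl group or a fluorine atom there, or a furan-2-yl group without its methyl, would separate these readings.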